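Series notes: cyclopentyl-bearing core, anilino-type side chain, amide methyl to ethyl

The compounds below may be only part of what the source reports. "The series", "measured", "known", "first", "only" and "open" are said of these compounds alone.

Measured compounds:
Compound 1, `CN1CCN(c2ccc(Nc3ncc4c(n3)N(C3CCCC3)CC(=O)N4C)cc2)CC1`: in an ADME assay on HEK293 cells (Homo sapiens) for inhibition, read by MTT assay, with a stated time of 48 h (on this read-out lower numbers stand for stronger inhibition and higher numbers for weaker inhibition), compound 1 gives 12400 nM.
Compound 2, `CN1CCN(c2ccc(Nc3ncc4c(n3)N(C3CCCC3)CC(=O)N4C)nc2)CC1`: in this assay compound 2 shows "not determined" (no result reported), so no result is reported for it.
Compound 3, `CCN1C(=O)CN(C2CCCC2)c2nc(Nc3ccc(N4CCN(C)CC4)cc3)ncc21`: in this assay compound 3 gives only a limit, > 30000 nM.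

Going by the values given here, the one measured step within the set runs an at least 2.4-fold higher number from compound 1 to compound 3 (0.38 log units; beyond the scatter). The change behind it is methyl in place of hydrogen on a saturated chain carbon bound to an amide-type nitrogen in a ring. The step can only be given as an at-least figure because the limit of > 30000 nM in this assay, at which 1 of the 3 values shown sits, marks where compound 3 sits.

Compound 2 and compound 1 differ in their cores; that difference between the two cores is not broken down here. Compound 4, `CCN1C(=O)CN(C2CCCC2)c2nc(Nc3ccc(N4CCN(C)CC4)cn3)ncc21`, stands to compound 2 as compound 3 stands to compound 1: the change is methyl in place of hydrogen on a saturated chain carbon bound to an amide-type nitrogen in a ring, the same kind of change as before, with the place line reading the same in both.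

Among the compounds with values here, what is expected from compound 2 to compound 4 in this assay is a step of the same kind as the earlier one, weakening inhibition by an amount comparable to an at least 2.4-fold higher number from compound 1 to compound 3 (0.38 log units; beyond the scatter), since that is the only measured instance of this change. With no result for compound 2 and compound 1 already weak at 12400 nM, compound 4 is expected to be weak as well. Compound 4 is estimated at 35000 nM, expected between 10000 nM and 120000 nM.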

Compound 4, half-maximal inhibitory concentration: > 30000 nM
Compound 4 gave a limit, no number (the forecaster's own chance of this, stated with the estimate: 60%); the middle value lies beyond the limit too.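

Going by these compounds alone, compound 2 has no reported result in this assay, and no step from it to compound 4 can be read. Compound 4 gives > 30000 nM, which is not a number but a limit, the one recorded here: the limit of > 30000 nM in this assay, at which 2 of the 4 values shown sit.

The compounds shown leave open how methyl to ethyl acts on the core of compound 2, and how much weaker than that limit compound 4 actually lies.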